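Chloro to bromo swap on the anilino group

The compounds below may be only part of what the source reports. "The series", "measured", "known", "first", "only" and "open" are said of these compounds alone.

compound 1 `Clc1cccc(Nc2ncnc3ccc(NCc4ccc5c(c4)OCCCO5)cc23)c1`: 31 ug/mL
compound 2 `O=C(Nc1ccc2ncnc(Nc3cccc(Br)c3)c2c1)C1COc2ccccc2O1`: 73.8 ug/mL
compound 3 `Brc1cccc(Nc2ncnc3ccc(NCc4ccc5c(c4)OCCCCO5)cc23)c1`: > 100 ug/mL

All three numbers come from a functional assay on A549 cells (Homo sapiens) for antiproliferative activity, read by WST assay, with a stated time of 48 h; a higher number here means a weaker inhibitor, a lower number a stronger inhibitor. Compound 1 holds the lowest of the two numbers; compound 2 sits higher, by a gap beyond the usual scatter. For compound 3 the assay returned only a limit, (the limit of > 100 ug/mL in this assay, at which 1 of the 3 values shown sits), not a number.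

Compound 4 `Brc1cccc(Nc2ncnc3ccc(NCc4ccc5c(c4)OCCCO5)cc23)c1` differs from compound 1 by bromo in place of chloro on an aromatic carbon. Among the measured compounds shown here, no measured pair isolates this swap; compound 3 also carries bromo, but its other ring differs too, so its limit says nothing about the swap alone.

In this assay compound 4 is expected to give 40 ug/mL, between 15 ug/mL and 100 ug/mL, with the step of a 1.3-fold higher number from compound 1 to compound 4 (0.11 log units; within the scatter) expected to be small, at most slightly toward weaker inhibition.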

Compound 4, half-maximal inhibitory concentration: 15.5 ug/mL
Beside the measured number, compound 4's estimate is 2.6-fold (0.41 log units) above it; the measured number falls inside the stated range.
By their numbers in this assay, from the lowest: compounds 4 and 1 (each within the scatter of the next); then compound 2. At a limit, above all of these: compound 3.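

The swap from 3-chlorophenyl to 3-bromophenyl can now be read alone: in this assay it gives a 2.0-fold lower number from compound 1 to compound 4 (0.30 log units; within the scatter). At this position, on this core, the two halogens are therefore not told apart. No measured property bears on this step.

From the compounds shown here alone, it remains open whether a methoxy group, an amine or a plain hydrogen at the same position would hold the number. Also open, going by these compounds, is whether the same swap reads alike with the other ring of compound 3.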